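Amide tail variation in a cytotoxicity series

The compounds below may be only part of what the source reports. "The series", "measured", "known", "first", "only" and "open" are said of these compounds alone.

Of the compounds shown here, three have been measured in a functional assay on MGC-803 cells (Homo sapiens) for cytotoxicity, read by MTT assay, with a stated time of 48 h; on this read-out higher numbers stand for weaker inhibition and lower numbers for stronger inhibition. Compound 1 `CC1=NN(C(=O)/C=C/c2ccccc2)C(c2ccccc2O)C1` gives 39600 nM, compound 2 `CC1=NN(C(=O)COc2ccc(Cl)cc2)C(c2cc(Br)cc(Br)c2O)C1` gives 50000 nM, and compound 3 `CNCC(=O)N1N=C(c2cc3ccccc3oc2=O)CC1c1ccccc1` gives 12800 nM. Compound 3 stands lowest of the three numbers and is thus the strongest inhibitor so far; its gap to compound 1 and its wider gap to compound 2 both lie beyond the scatter. For the measured compounds named here, no pair of measured compounds differs in a single place, so no measured step exists yet from which the effect of a change at one site could be read.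

Compound 4 `NC(=O)C1CCN(CC(=O)N2N=C(c3cc4ccccc4oc3=O)CC2c2ccccc2)CC1` is the next member and has not been measured in this assay. It differs from compound 3 in one place: 4-carbamoylpiperidin-1-yl in place of methylamino on a saturated chain carbon bound to a carbonyl carbon. Everything else in the molecule is kept. Going by the values given here, since no step of this kind has been measured, the step of a 1.2-fold lower number from compound 3 to compound 4 (0.07 log units; within the scatter) is expected to be modest, with no clear direction, and most likely not beyond the scatter of repeated measurements. On that basis compound 4 is estimated at 11000 nM, with a range from 4000 nM to 32000 nM.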

Compound 4, half-maximal inhibitory concentration: 21500 nM
For compound 4 the middle estimate is 2.0-fold (0.29 log units) below the measured one; the measured number falls inside the stated range.
By their numbers in this assay, from the lowest: compounds 3, 4, 1 and 2 (each within the scatter of the next, the first and the last beyond it).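

In this assay, for the compounds shown here, the single-site step at this saturated chain carbon bound to a carbonyl carbon is a 1.7-fold higher number from compound 3 to compound 4 (0.23 log units; within the scatter), the first reading for this position, which compounds 1 and 2 could not give as they differ from compound 3 in more than one place. Replacing methylamino with the larger 4-carbamoylpiperidin-1-yl, which brings a six-membered non-aromatic ring and a carbamoyl group, therefore leaves the number within the scatter, so this one change gives no sign that the position is sensitive to added bulk. No measured data on hand explain this outcome.

Going by these compounds alone, the single step cannot separate any contribution of the piperidine ring from that of its carbamoyl group, a question that a plain piperidin-1-yl or a morpholin-4-yl group at the same carbon would address. It also leaves open whether any group at this position can move the number beyond the scatter, for instance a dimethylamino group, or a carboxylic acid in place of the carbamoyl group on the piperidine ring.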